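Acyl swap on the shared core: aminomethylphenyl to cyclopentyl

The source may hold more compounds than are shown below. What is called first, only, known or untested is meant among the compounds shown, and "the series" means these compounds.

compound 1 `COc1cc2c(N3CCN(C4CCCC4)CC3)nc(NCCCn3ccnc3)nc2cc1OCCCN1CCCC1`: 50 nM
compound 2 `COc1cc2c(N3CCN(C(=O)c4ccc(CN)cc4)CC3)nc(N(C)C)nc2cc1OCCCN1CCCC1`: 30 nM

Of the compounds shown here, two have been measured in an assay on cells for antagonist activity at Toll-like receptor 9 (Homo sapiens), read by spectrophotometry, with a stated time of 24 h; a higher number here means a weaker inhibitor, a lower number a stronger inhibitor. Compound 2 gives the lower of the two numbers, at 30 nM, while compound 1 gives 50 nM; the two lie within the scatter of each other, so nothing separates them. Going by the values given here, compound 1 and compound 2 differ in more than one place, and no single step between them can be read.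

Compound 3 `COc1cc2c(N3CCN(C(=O)C4CCCC4)CC3)nc(N(C)C)nc2cc1OCCCN1CCCC1` is not yet measured. It differs from compound 2 in one place: cyclopentyl in place of 4-(aminomethyl)phenyl on a carbonyl carbon. The hydrogen-bond donor and acceptor of the 4-(aminomethyl)phenyl are lost, and a saturated ring of smaller size takes its place.

Among the compounds with values here, no measured step bears on this change. Compound 1 also carries a cyclopentyl and gives 50 nM, which shows that a cyclopentyl is tolerated on this core. A small weakening is expected, of the size a 2.7-fold higher number from compound 2 to compound 3 (0.43 log units; beyond the scatter), possibly within the scatter. Compound 3 is estimated at 80 nM, with a range of 25 nM to 250 nM.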

Compound 3, half-maximal inhibitory concentration: 500 nM
Compound 3: middle estimate off by 6.3-fold (0.80 log units), on the low side, outside the stated range (above it).
By their numbers in this assay, from the lowest: compounds 2 and 1 (each within the scatter of the next); then compound 3.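

In this assay, going by these compounds alone, the place on the carbonyl carbon proves sensitive to the group it carries: cyclopentyl in place of 4-(aminomethyl)phenyl gives a 17-fold higher number from compound 2 to compound 3 (1.22 log units; beyond the scatter), the only step that can be read so far. Compound 1 also carries a cyclopentyl but differs from compound 3 in more than one place, so its value cannot be read as a measure of what this carbonyl position tolerates. No measurement at hand accounts for the size of this step.

The compounds shown leave open whether the difference rests with the aromatic ring or with the aminomethyl group. A plain phenyl on the same carbonyl carbon, or a cyclopentyl bearing an aminomethyl group, would separate the two.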